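The compounds below may be only part of what the source reports. "The series", "measured", "known", "first", "only" and "open" are said of these compounds alone.

Measured compounds:
compound 1, `COc1cc(C)nc(C(=O)Nc2nn[nH]n2)c1`, 20%
compound 2, `CCCCc1cccc(C(=O)Nc2nn[nH]n2)n1`, 18%
compound 3, `COc1ccnc(C(=O)Nc2nn[nH]n2)c1`, 88%

All three were tested in a functional assay on the whole organism for inhibition, with Rattus norvegicus as the target, at a dose of 10 mg/kg by the oral route; on this read-out lower numbers stand for a weaker effect and higher numbers for a stronger effect at the one dose given. Compound 2 gives the lowest of the three numbers in this assay, at 18%. Its nearest neighbour is compound 1, whose 20% lies within the scatter of it, so the two cannot be told apart. Compound 3, at 88%, stands far above both.

Compound 4, `CCCc1cccc(C(=O)Nc2nn[nH]n2)n1`, has not yet been measured. It differs from compound 2 in one place: hydrogen in place of methyl on a saturated chain carbon, three bonds along the chain from an aromatic carbon.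

Among the compounds with values here, only one measured step exists, a number 68 percentage points higher from compound 1 to compound 3 (beyond the scatter), and it removes a methyl from an aromatic carbon, not from a saturated chain, so it bears on the present change only loosely. It does show that losing a methyl can go with a strongly higher read-out in this assay. Against that, compounds 1 and 2 both carry a chain or methyl on the core and both sit low. A modest rise is therefore expected, a number 12 percentage points higher from compound 2 to compound 4 (beyond the scatter). Compound 4 is estimated at 30% in this assay, between 10% and 65%.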

Compound 4, a percentage reported as inhibition, in the whole organism at one dose (the size of the read-out at that dose, not a potency): 38%
For compound 4 the middle estimate is 8 percentage points below the measured one; the measured number falls inside the stated range.
By their numbers in this assay, from the lowest: compounds 2 and 1 (each within the scatter of the next); then compound 4; then compound 3.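

Cutting the butyl chain back to propyl gives a number 20 percentage points higher from compound 2 to compound 4 (beyond the scatter) in this assay and so shows that this read-out responds to a change on the saturated chain itself, not only on an aromatic carbon. Removing one methyl from the far end of the chain is enough to move the number beyond the usual scatter, so the end of this chain is not a silent part of compound 2. Nothing available here explains why this change raises the number.

A single step cannot show whether the number would keep rising with an ethyl chain, or fall further with a longer chain such as pentyl. On these data alone, how a chain ending in an amine or a carboxylic acid would behave also remains open.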